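Adding a methoxy group to compound 3

A few compounds are considered here, and "the series" means these few. Any claim that something is new, unique, unknown or untested is made for them only; others in the source may bear on it.

Measured in a functional assay on the whole organism (strain BALB/c) with Mus musculus as the target, with a stated time of 4 h; a lower number here means that less compound is needed, a higher number that more compound is needed for the effect:
- compound 1 `CC1=C(CN2CC(C(=O)O)C2)CCc2cc(OCC3Cc4ccccc4C3)ccc21`: > 1 mg/kg
- compound 2 `CC1=C(CN2CC(C(=O)O)C2)CCc2cc(OCCC3CCc4ccccc43)ccc21`: > 1 mg/kg
- compound 3 `CC1=C(CN2CC(C(=O)O)C2)CCc2cc(OCc3ccc(CC(C)C)cc3)ccc21`: 0.39 mg/kg

Compound 1 gives only a limit, not a number. Compound 2 also gives only a limit. Among the compounds with values here, compound 3 holds the one true number, 0.39 mg/kg. The measured steps are an at least 2.5-fold lower number from compound 1 to compound 3 (0.40 log units; beyond the scatter) and an at least 2.5-fold lower number from compound 2 to compound 3 (0.40 log units; beyond the scatter), and both swap the whole group carried on the chain.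

Compound 4 `COc1cc(COc2ccc3c(c2)CCC(CN2CC(C(=O)O)C2)=C3C)ccc1CC(C)C` keeps that 4-isobutylphenyl group and adds methoxy in place of hydrogen on an aromatic carbon: methoxy in place of hydrogen, ortho to an isobutyl group. Within the data shown here, no measured step adds such a small group, so those two steps offer only weak guidance. Little change is therefore expected in this assay, with a slightly higher number and nothing beyond the scatter. The expected size is a 1.3-fold higher number from compound 3 to compound 4 (0.11 log units; within the scatter). For compound 4 the estimated value is 0.5 mg/kg, with an expected range from 0.15 mg/kg to 1.5 mg/kg.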

Compound 4, dose for half-maximal effect: 0.034 mg/kg
For compound 4 the middle estimate is 15-fold (1.17 log units) above the measured one; the measured number lies below the stated range.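

In this assay, methoxy in place of hydrogen, ortho to an isobutyl group, gives an 11-fold lower number from compound 3 to compound 4 (1.06 log units; beyond the scatter). The earlier steps shown here swapped the whole group on the chain, whereas this one shows that a single aromatic carbon on the 4-isobutylphenyl ring can strongly change the dose needed. Nothing shown here explains this gain. As far as these compounds go, whether a hydroxyl, a chlorine or a longer ethoxy on this carbon would act in the same way remains open. So does the effect of methoxy on the other carbons of this ring.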